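The compounds below may be only part of what the source reports. "The series", "measured", "known", "first", "only" and "open" are said of these compounds alone.

Measured to date:
compound 1 `COc1cc(C(=O)NC2CCN(C)CC2)ccc1Nc1ncc(Br)c(NC2CCCC2)n1`: 4900 nM
compound 2 `CN1CCN(c2ccc(Nc3ncc(F)c(NC4CCCC4)n3)cc2)CC1`: 25000 nM
compound 3 `CCCNc1nc(Nc2ccc(N3CCN(C)CC3)cc2)ncc1F`: 35000 nM

In a functional assay on HepG2 cells (Homo sapiens) for cytotoxicity, read by MTT assay, with a stated time of 48 h (a lower number here means a stronger inhibitor, a higher number a weaker inhibitor), compound 2 gives 25000 nM, the second highest of the three numbers. Within the data shown here, compound 3 is nearest, and the only single-point step in the set, a 1.4-fold higher number from compound 2 to compound 3 (0.15 log units; within the scatter), stays within the scatter. Compound 1, with 4900 nM, stands furthest off, a gap beyond the scatter. Compound 4 `CN1CCC(NC(=O)c2ccc(Nc3ncc(F)c(NC4CCCC4)n3)cc2)CC1` is not yet measured. It differs from compound 2 by (1-methylpiperidin-4-yl)carbamoyl in place of 4-methylpiperazin-1-yl on an aromatic carbon. The step from compound 2 to compound 3 alters a different part of the molecule and bears only loosely on this change. Compound 1 carries the same entering group but differs from compound 2 at more than one place, so its lower number is only a rough pointer. Compound 4 is therefore expected to show a step of a 2.8-fold lower number from compound 2 to compound 4 (0.44 log units; beyond the scatter), downward but uncertain in size. The estimate for compound 4 is 9000 nM, in the range 3500 nM to 25000 nM.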

Compound 4, half-maximal inhibitory concentration: 10000 nM
Beside the measured number, compound 4's estimate is 1.1-fold (0.05 log units) below it; the measured number falls inside the stated range.
By their numbers in this assay, from the lowest: compound 1; then compound 4; then compounds 2 and 3 (each within the scatter of the next).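

In this assay, (1-methylpiperidin-4-yl)carbamoyl in place of 4-methylpiperazin-1-yl gives a 2.5-fold lower number from compound 2 to compound 4 (0.40 log units; beyond the scatter) on an otherwise unchanged core. Among these compounds, this is the first single-place reading at this aromatic carbon, para to a large group, and the change lies beyond the scatter, which compound 1 could only suggest. Nothing measured here accounts for the step.

Still open, on these data alone, is whether the carbonyl or the ring swap carries the step: a 4-methylpiperazine-1-carbonyl group at this carbon would separate them. As far as these compounds go, whether propyl in place of cyclopentyl reads the same alongside (1-methylpiperidin-4-yl)carbamoyl also remains open.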